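A few compounds are considered here, and "the series" means these few. Any claim that something is new, unique, unknown or untested is made for them only; others in the source may bear on it.

Of the compounds shown here, three sharing a common core have so far been measured in a functional assay on A2780 cells (Homo sapiens) for inhibition, with a stated time of 72 h; a lower number here means a stronger inhibitor, a higher number a weaker inhibitor. Compound 1, `CC1(C)CCOc2ccc(NC(=O)Nc3ccc([N+](=O)[O-])cc3)cc21`, gives 6700 nM. Compound 2, `CC1(C)CCOc2ccc(NC(=S)Nc3ccc(OC(F)(F)F)cc3)cc21`, gives 4300 nM. Compound 3, `CCC1(CC)CC(C)(C)Oc2ccc(NC(=S)Nc3ccc([N+](=O)[O-])cc3)cc21`, gives 3690 nM. Compound 3 carries the lowest of the three numbers, but its separation from compound 2 and from compound 1 is within the scatter of repeated measurements, so no order among the three can be read from these values.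

Compound 4, `CCC1(CC)CC(C)(C)Oc2ccc(NC(=S)Nc3ccc(C(F)(F)F)cc3)cc21`, has not yet been measured. It differs from compound 3 in a single place: trifluoromethyl in place of nitro on an aromatic carbon. For the measured compounds named here, no step of exactly this kind exists between two measured compounds, so the direction has to be judged without a direct precedent. What the measured values do show is that compound 1 and compound 2, which differ from each other both in the core and in the group on the outer aromatic ring, still come out within the scatter of one another and of compound 3. That gives little reason to expect a large move in either direction when trifluoromethyl replaces nitro.

The step from compound 3 to compound 4 is therefore expected to be a 1.1-fold lower number from compound 3 to compound 4 (0.02 log units; within the scatter), a change not clearly beyond the scatter. Compound 4 is estimated at 3500 nM, within a range from 1500 nM to 8500 nM.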

Compound 4, half-maximal inhibitory concentration: 4700 nM
For compound 4 the middle estimate is 1.3-fold (0.13 log units) below the measured one, and the stated range covers the measured number.
By their numbers in this assay, from the lowest: compounds 3, 2, 4 and 1 (each within the scatter of the next).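

In this assay, the exchange of nitro for trifluoromethyl on an aromatic carbon, para to a large group, gives a 1.3-fold higher number from compound 3 to compound 4 (0.11 log units; within the scatter). For the compounds shown here, this is the first comparison in which only one group differs, which the earlier compounds could not provide because they differ in more than one place. At this position, 4-nitrophenyl and 4-(trifluoromethyl)phenyl cannot be told apart by their numbers, even though the nitro group is counted with hydrogen-bond acceptors and the trifluoromethyl group with none, and no measurement shown here speaks to the reason for this result.

The compounds shown leave open whether any other group at this position, such as an amine, a carboxylic acid, a methoxy group or a longer chain, would move the number beyond the scatter. Going by these compounds alone, they also leave open whether the position responds at all, as the only single-place step available stays within the scatter and a hydrogen atom in place of these groups does not appear among them.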